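Swapping chloro for methyl on an inactive compound

The compounds below may be only part of what the source reports. "The series", "measured", "known", "first", "only" and "open" are said of these compounds alone.

Values from a functional assay on ACHN cells (Homo sapiens) for antiproliferative activity, read by XTT assay; on this read-out higher numbers stand for weaker inhibition and lower numbers for stronger inhibition (lines marked "limit" give no exact number):
- Compound 1 (`O=c1c(/C=C/c2coc3ccccc3c2=O)coc2ccccc12`) gives > 10000 nM (limit)
- Compound 2 (`O=c1c(Cc2coc3cccc(OCC4CCCCC4)c3c2=O)coc2cc(Cl)ccc12`) gives > 10000 nM (limit)
- Compound 3 (`CC(C)CCOc1cccc2occ(Cc3coc4ccccc4c3=O)c(=O)c12`) gives 3960 nM (a measured number)

Compound 2 stands at the limit of > 10000 nM in this assay, at which 2 of the 3 values shown sit, and so has a limit, not an exact number. Compound 4 (`Cc1ccc2c(=O)c(Cc3coc4cccc(OCC5CCCCC5)c4c3=O)coc2c1`) has not been measured yet. Compared with compound 2 it shows methyl in place of chloro on an aromatic carbon. Among the measured compounds shown here, no measured pair shows this swap, so the expectation stays cautious. Expected is a number no higher from compound 2 to compound 4 (the limit leaves the size open) (no shift beyond the usual scatter, in either direction). Compound 4 is expected to give about 10000 nM (estimated range 4000 nM to 20000 nM).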

Compound 4, half-maximal inhibitory concentration: 2250 nM
Beside the measured number, compound 4's estimate is 4.4-fold (0.65 log units) above it, and the stated range ends above it.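

In this assay, methyl in place of chloro on an aromatic carbon gives an at least 4.4-fold lower number from compound 2 to compound 4 (0.64 log units; beyond the scatter). Among the compounds shown here, this is the first sign that this carbon, meta to a fused ring and para to a fused ring, matters here: exchanging one heavy atom for another takes the compound from a limit to a measured number. The full size of the step stays unknown because compound 2 gives only a limit: the limit of > 10000 nM in this assay, at which 2 of the 4 values shown sit.

From the compounds shown here alone, it remains open whether a methoxy group or an amine at this carbon would give a lower number than methyl. Going by these compounds, it is also open whether methyl there would lower the number of compound 3.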